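Methyl to Methoxy on Two Different Sulfone Cores

The source may hold more compounds than are shown below. What is called first, only, known or untested is meant among the compounds shown, and "the series" means these compounds.

Compound 1 `Cc1ccc(S(=O)(=O)c2cnc3c(F)cccc3c2N2CCC(C)CC2)cc1`: 93%
Compound 2 `COc1ccc(S(=O)(=O)c2cnc3c(F)cccc3c2N2CCC(C)CC2)cc1`: 67%
Compound 3 `Cc1ccc2ncc(S(=O)(=O)c3cccc(C#N)c3)c(N3CCC(C)CC3)c2c1`: 52%

All three were tested in an assay on isolated protein for displacement of a labelled ligand from metabotropic glutamate receptor 5 (Homo sapiens), with a stated time of 60 min, tested at 1 uM; a higher number here means more inhibition at the concentration tested (going by the name of the read-out), a lower number less inhibition. Compound 1 and compound 2 differ in one spot only, (methoxy in place of methyl on an aromatic carbon), and that change gave a number 26 percentage points lower from compound 1 to compound 2 (beyond the scatter). Compound 3 has the lowest of the three measured numbers; the difference between its core and the core of compound 1 is not broken down here. Compound 4 `COc1ccc2ncc(S(=O)(=O)c3cccc(C#N)c3)c(N3CCC(C)CC3)c2c1` is not yet measured and relates to compound 3 by the same kind of change, (methoxy in place of methyl on an aromatic carbon). The place is not the same: in compound 1 the group sits para to a large group, whereas in compound 3 it sits on a ring that is part of a fused or bridged system of two rings, meta to a fused ring and para to a fused ring. Within the data shown here, for compound 4 a step of a number 20 percentage points lower from compound 3 to compound 4 (beyond the scatter) is expected, because a number 26 percentage points lower from compound 1 to compound 2 (beyond the scatter) is the only guide available. Compound 4 is estimated at 32%, between 10% and 55%.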

Compound 4, a percentage reported as inhibition, at one concentration (the size of the read-out at that concentration, not a potency): 90%
Compound 4: middle estimate off by 58 percentage points, on the low side; the whole stated range lies below it.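

In this assay, methoxy in place of methyl gave a number 38 percentage points higher from compound 3 to compound 4 (beyond the scatter), so the same change went in opposite directions on the two cores: the same change on two cores in this assay, a number 26 percentage points lower (beyond the scatter) from compound 1 to compound 2 and a number 38 percentage points higher (beyond the scatter) from compound 3 to compound 4, 64 percentage points apart, beyond the scatter of two such steps

A step measured on the core of compound 1 thus gives no safe guide to the same change on the core of compound 3. These two pairs do not show what lies behind the reversal, as the cores differ in several places and the group stands in a different place on each, and they set no rule for other cores.

Still open, going by these compounds, is whether the methoxy step would keep its direction if the nitrile and the fluorine were exchanged between the cores. On these data alone, how an ethoxy group or an amine on the same carbon would read on either core also remains open.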